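The source may report more compounds than this note shows. Statements on the series, on what has been measured and on what is new or still open speak of the compounds shown alone.

In a functional assay on THP-1 cells (Homo sapiens) for inhibition (a lower number here means a stronger inhibitor, a higher number a weaker inhibitor), compound 1 `COc1cccc(C(=O)NNC(=O)C2(C(=O)N[C@H]3CC(=O)OC3O)CCC2)c1` gives 400 nM and compound 2 `COc1cccc(C(=O)NNC(=O)C2(C(=O)N[C@H]3CC(=O)OC3O)CCCCC2)c1` gives 1300 nM, so compound 2 has the higher of the two numbers and is the weaker inhibitor of the pair. Compound 3 `Cc1cccc(C)c1C(=O)NNC(=O)C1(C(=O)N[C@H]2CC(=O)OC2O)CCCCC1` differs from compound 2 in one place: 2,6-dimethylphenyl in place of 3-methoxyphenyl on a carbonyl carbon, with 2,6-dimethylphenyl in place of 3-methoxyphenyl on a carbonyl carbon. Among the measured compounds shown here, no measured pair shows the effect of this change, so no step beyond the scatter is expected in this assay, though this expectation is uncertain. The expected step is a 1.2-fold lower number from compound 2 to compound 3 (0.07 log units; within the scatter). For compound 3 the estimated value is 1100 nM, with a range of 300 nM to 4000 nM.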

Compound 3, half-maximal inhibitory concentration: >= 2500 nM
Compound 3: a limit, no number; the forecaster's own chance of this, stated with the estimate: 5%; at least 2.2-fold (0.35 log units) between middle value and limit.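

In this assay compound 3 is reported only as a limit, not a number: the limit of >= 2500 nM in this assay, at which 1 of the 3 values shown sits.

The earlier compounds shown here kept 3-methoxyphenyl fixed on the carbonyl carbon, whereas 2,6-dimethylphenyl there gives an at least 1.9-fold higher number from compound 2 to compound 3 (0.28 log units; that floor lies within the scatter). Among the compounds shown here, this is the first view of a change at this position, but its floor lies within the scatter and the true size of the step remains unknown.

The compounds shown leave open how a plain phenyl would compare at this position. They also leave open how a phenyl carrying an amine or a carboxylic acid would read in this assay.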